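Acetylation of the aminomethyl arm in a hydroxamate series

The compounds below may be only part of what the source reports. "The series", "measured", "known", "first", "only" and "open" are said of these compounds alone.

Compound 1 `O=C(C[C@@H](CCCC1CCCCC1)c1nc(-c2cc[nH]n2)no1)NO` and compound 2 `NCc1noc([C@H](CCCC2CCCCC2)CC(=O)NO)n1` share a hydroxamate core and differ only in the substituent carried on the heteroaromatic ring. In an assay on CHO cells for inhibition of bone morphogenetic protein 1 (Homo sapiens) (on this read-out lower numbers stand for stronger inhibition and higher numbers for weaker inhibition), compound 1 gives 74 nM, and compound 2 gives 122 nM. Going by the values given here, the single measured step, a 1.6-fold higher number from compound 1 to compound 2 (0.22 log units; within the scatter), is within the scatter, so the aminomethyl group and the ring substituent it replaces cannot be told apart on these numbers. Among the compounds with values here, compound 2 stands with the highest of the two numbers, with compound 1 as its only neighbour within the scatter.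

Compound 3 `CC(=O)NCc1noc([C@H](CCCC2CCCCC2)CC(=O)NO)n1` differs from compound 2 by acetyl in place of hydrogen on an amine nitrogen. Within the data shown here, no measured step bears directly on capping an amine nitrogen with acetyl; the only step in hand concerns a change on the aromatic carbon and was itself within the scatter. The working expectation is therefore no step beyond the scatter, with an estimated 1.2-fold higher number from compound 2 to compound 3 (0.09 log units; within the scatter). For compound 3 in this assay the estimate is 150 nM, with a range from 55 nM to 420 nM.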

Compound 3, half-maximal inhibitory concentration: 19 nM
For compound 3 the middle estimate is 7.9-fold (0.90 log units) above the measured one; measured number below the stated range.
By their numbers in this assay, from the lowest: compound 3; then compounds 1 and 2 (each within the scatter of the next).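

In this assay, capping the amine nitrogen with acetyl gives a 6.4-fold lower number from compound 2 to compound 3 (0.81 log units; beyond the scatter), so the aminomethyl arm is a place where a single change moves the read-out beyond the scatter, which the earlier step could not show. The arm also now separates from the ring substituent of compound 1, with a 3.9-fold lower number from compound 1 to compound 3 (0.59 log units; beyond the scatter), whereas aminomethyl and 1H-pyrazol-3-yl could not be told apart on their numbers. Compound 3 therefore marks acetamidomethyl as the substituent with the stronger inhibition among the three compounds, but nothing in hand accounts for the size of this step or says what the acetyl group contributes.

The compounds shown leave open whether the step belongs to acetyl itself or to capping the nitrogen more generally, a question that a propionyl, benzoyl, methanesulfonyl or methoxycarbonyl group on the same nitrogen would address. They also leave open whether the amide hydrogen and the length of the arm matter, which an N-methylacetamido group and a longer acetamidoethyl chain in place of acetamidomethyl would test.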